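The source may report more compounds than this note shows. Statements on the series, on what has been measured and on what is new or still open speak of the compounds shown alone.

Compound 1 `CC(C)=CCOc1cc(Nc2nccs2)ccc1C` and compound 2 `CC(C)=CCOc1cc(Nc2nccs2)ccc1Cl` share a core and differ in one place: chloro in place of methyl on an aromatic carbon. Both were tested in a functional assay on MT2 cells (Homo sapiens) for cytotoxicity, read by MTT assay; on this read-out higher numbers stand for lower toxicity in this test and lower numbers for higher toxicity in this test. In this assay compound 1 gives 17000 nM. In this assay compound 2 gives 26000 nM. The step between them is a 1.5-fold higher number from compound 1 to compound 2 (0.18 log units; within the scatter), so on this read-out the two cannot be told apart.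

Compound 3 `CC(C)=CCOc1cc(Nc2nc(C)cc(N)n2)ccc1Cl` carries a different core; how its core differs from that of compound 1 is not broken down here. In this assay compound 3 is reported only as a limit, < 4 nM, and not as a number. This is the limit of < 4 nM in this assay, at which 1 of the 3 values shown sits.

Compound 4 `CC(C)=CCOc1cc(Nc2nc(N)cc(Cl)n2)ccc1Cl` has not yet been tested. It differs from compound 3 by chloro in place of methyl on an aromatic carbon. Among the compounds with values here, this is the same kind of change as the one from compound 1 to compound 2, though the place is not the same: there the chloro entered on an aromatic carbon of a six-membered aromatic ring of carbon only, ortho to a (3-methylbut-2-en-1-yl)oxy group and para to a (1,3-thiazol-2-yl)amino group, whereas here it enters on a six-membered aromatic ring with 2 nitrogen, next to the ring nitrogen, meta to a large group and meta to an amino group.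

The expected step is a number no lower from compound 3 to compound 4 (the limit leaves the size open), resting on the earlier step of a 1.5-fold higher number from compound 1 to compound 2 (0.18 log units; within the scatter) staying within the scatter and on compound 3 sitting at the limit < 4 nM. Compound 4 is therefore expected to give about 4 nM in this assay, most likely again reported only as a limit, within a range from 1 nM to 20 nM.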

Compound 4, half-maximal cytotoxic concentration: 14 nM
For compound 4 the middle estimate is 3.5-fold (0.54 log units) below the measured one, within the range that was stated.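

In this assay, putting chloro in place of methyl on the aromatic carbon of the six-membered aromatic ring with 2 nitrogen gives an at least 3.5-fold higher number from compound 3 to compound 4 (0.54 log units; beyond the scatter), a step beyond the usual scatter, while the same kind of change on the other core gave a 1.5-fold higher number from compound 1 to compound 2 (0.18 log units; within the scatter), a step within it. On the core of compound 3, then, the change gives two compounds that can be told apart, with compound 4 on the side of lower toxicity in this test, whereas on the core of compound 1 the two compounds cannot be told apart. This does not show that the change has a larger effect on one core than on the other, as compound 3 has only a limit and not a number: the same change on two cores in this assay, a 1.5-fold higher number (0.18 log units; within the scatter) from compound 1 to compound 2 and an at least 3.5-fold higher number (0.54 log units; beyond the scatter) from compound 3 to compound 4; the limit leaves it open whether they differ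

The series holds just one such pair on each core, so no general rule for this change can be drawn from it. The compounds shown also leave open how fluoro, bromo, methoxy or a nitrile would read at the same ring carbon in this assay, where only methyl and chloro appear here.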